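This account rests on a few compounds, and the source may have more. Where it says the series, first, only, none or still open, it means among the compounds named here.

Compound 1 `COc1cc(C)cc(-c2c(-c3ccnc(-c4ccc(C(C)=O)cc4)c3)cnn2CC#N)c1` carries an acetyl group on the phenyl ring that hangs from its core. In a functional assay on Hs-578T cells (Homo sapiens) for inhibition, read by sulforhodamine B assay, with a stated time of 48 h (a higher number here means a weaker inhibitor of growth, a lower number a stronger inhibitor of growth), compound 1 gives 1680 nM. Two related compounds share the same core but differ on that distal ring and elsewhere: compound 2 `Cc1cc(O)cc(-c2nn(CC#N)cc2-c2ccnc(-c3ccc(Oc4ccccc4)cc3)c2)c1` gives 2020 nM in this assay, and compound 3 `Cc1cc(O)cc(-c2nn(CC#N)cc2-c2ccnc(-c3ccc(N(C)C)cc3)c2)c1` gives 2130 nM. The three numbers sit together, and the gaps from compound 1 to either companion lie within the scatter of repeated measurements, so no one of them can be called the stronger inhibitor of growth.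

The change considered here leads from compound 1 to compound 4 `COc1cc(C)cc(-c2c(-c3ccnc(-c4ccc(N(C)C)cc4)c3)cnn2CC#N)c1`, which has not been measured. The difference is dimethylamino in place of acetyl on an aromatic carbon. Within the data shown here, only one measured step touches this position: a 1.1-fold higher number from compound 2 to compound 3 (0.02 log units; within the scatter), which brought dimethylamino onto that ring in place of phenoxy without moving the number beyond the scatter. Among the measured compounds shown here, no measured pair shows acetyl giving way to dimethylamino directly. On that single precedent the account expects no shift beyond the scatter, and the step of a 1.1-fold higher number from compound 1 to compound 4 (0.03 log units; within the scatter) is the estimate that follows. Compound 4 is therefore expected to give about 1800 nM in this assay, with a plausible range from 900 nM to 3600 nM.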

Compound 4, concentration for 50% growth inhibition: 166 nM
For compound 4 the middle estimate is 11-fold (1.04 log units) above the measured one, and the stated range ends above it.
By their numbers in this assay, from the lowest: compound 4; then compounds 1, 2 and 3 (each within the scatter of the next).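

On the shared core of compound 1, the position on the distal phenyl ring turns out to be sensitive in this assay: going from 4-acetylphenyl to 4-(dimethylamino)phenyl gives a 10-fold lower number from compound 1 to compound 4 (1.01 log units; beyond the scatter), so compound 4 is a clearly stronger inhibitor of growth than compound 1. Among these compounds, the earlier compounds gave no sign of this, since the only step at this position, a 1.1-fold higher number from compound 2 to compound 3 (0.02 log units; within the scatter), brought in the same dimethylamino group in place of phenoxy, on a compound that differs from compound 1 elsewhere as well, and it stayed within the scatter; dimethylamino therefore does not carry the same size of step in both settings. Nothing in the data given explains this difference between the two steps.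

The compounds shown leave open whether the large step belongs to the loss of acetyl, the arrival of dimethylamino, or the rest of the molecule around them, a question that phenoxy on the core of compound 1 would address directly. They also leave open how far the result extends to neighbouring groups at this position, such as an unsubstituted amine, diethylamino or a morpholine ring.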